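Working notes: methoxy added to compound 1

A few compounds are considered here, and "the series" means these few. Any claim that something is new, unique, unknown or untested is made for them only; others in the source may bear on it.

In a functional assay on HeLa cells (Homo sapiens) for antiproliferative activity, read by MTT assay, with a stated time of 48 h (a lower number here means a stronger inhibitor, a higher number a weaker inhibitor), compound 1 (`O=[N+]([O-])c1cccc(-c2nn(-c3ccccc3)cc2C(Nc2nc3ccccc3s2)c2c(O)ccc3ccccc23)c1`) gives 8220 nM and compound 2 (`Cc1cccc(-c2nn(-c3ccccc3)cc2C(Nc2nc3ccccc3s2)c2c(O)ccc3ccccc23)c1`) gives 7020 nM in the same read-out. Among the compounds with values here, these are the only two numbers so far, and they lie within the scatter of each other, so compound 1 holds no distinct place. Within the data shown here, the one measured step (a 1.2-fold lower number from compound 1 to compound 2 (0.07 log units; within the scatter)) is methyl in place of nitro on an aromatic carbon, at another place in the molecule, and says nothing direct about the change considered here. Compound 3 (`COc1ccc2nc(NC(c3cn(-c4ccccc4)nc3-c3cccc([N+](=O)[O-])c3)c3c(O)ccc4ccccc34)sc2c1`) carries methoxy in place of hydrogen on an aromatic carbon, turning 1,3-benzothiazol-2-yl into 6-methoxy-1,3-benzothiazol-2-yl. Among the measured compounds shown here, no measured step touches that place, so no direction can be argued, and no shift beyond the scatter is expected in this assay on this evidence. The estimated step stays within that scatter (a 1.1-fold lower number from compound 1 to compound 3 (0.04 log units; within the scatter)) with either direction open. Compound 3 is expected at 7500 nM with an estimated range from 2500 nM to 20000 nM in this read-out.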

Compound 3, half-maximal inhibitory concentration: 6140 nM
The estimate for compound 3 lay 1.2-fold (0.09 log units) above the measured number; the range from low to high includes it.
By their numbers in this assay, from the lowest: compounds 3, 2 and 1 (each within the scatter of the next).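

Turning 1,3-benzothiazol-2-yl into 6-methoxy-1,3-benzothiazol-2-yl gives the first reading at this position in this assay (a 1.3-fold lower number from compound 1 to compound 3 (0.13 log units; within the scatter)). Methoxy on this aromatic carbon, meta to a fused ring and para to a fused ring, therefore leaves the number of compound 3 indistinguishable from that of compound 1, and a second place on the molecule now joins the nitro-to-methyl change (a 1.2-fold lower number from compound 1 to compound 2 (0.07 log units; within the scatter)) in producing no step beyond the scatter. No evidence is available that bears on this result.

Still open, as far as these compounds go, is whether an amine, a carboxylic acid or a longer chain such as ethoxy on the same aromatic carbon would move the number beyond the scatter. Also open, from the compounds shown here alone, is whether methoxy at this position reads the same with methyl in place of the nitro, as in compound 2.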